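This account rests on a few compounds, and the source may have more. Where it says the series, first, only, none or still open, it means among the compounds named here.

Working notes on the series. Three compounds have been run: compound 1 `COc1ccc(C(=O)CCc2ccc(OC)cc2OC)c(O)c1`, compound 2 `COc1ccc(CCCc2ccc(OC)c(OC)c2OC)c(O)c1` and compound 3 `COc1ccc(CCC(=O)c2ccc(OC)cc2O)cc1`. A fourth, compound 4 `COc1ccc(CCCc2cccc(OC)c2OC)c(O)c1`, is still to be run.

In an ADME assay on RAW264.7 cells (Mus musculus) for cytotoxicity, read by MTT assay, with a stated time of 24 h, tested at 2.5 ug/mL (on this read-out lower numbers stand for a stronger effect and higher numbers for a weaker effect at the one concentration tested), compound 1 gives 96.2%. In this assay compound 2 gives 95.5%, and compound 3 gives 94.5%. All three values sit within the scatter of one another, so no ordering among them is claimed.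

Among the measured compounds shown here, the only counted step is hydrogen in place of methoxy on an aromatic carbon, which gave a number 1.7 percentage points lower from compound 1 to compound 3 (within the scatter). The difference between the core of compound 1 and the core of compound 2 is not broken down here.

The change from compound 2 to compound 4 is hydrogen in place of methoxy on an aromatic carbon. It is the same kind of change as that from compound 1 to compound 3, but the surroundings differ: in compound 1 the leaving methoxy sits ortho to a large group and meta to a methoxy group, whereas in compound 2 it sits ortho to a methoxy group, meta to a methoxy group and para to a large group.

Because a number 1.7 percentage points lower from compound 1 to compound 3 (within the scatter) stayed within the scatter, a similarly small step a number 0.5 percentage points lower from compound 2 to compound 4 (within the scatter) is expected in this assay. Compound 4 is estimated to give 95%, between 87% and 101%.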

Compound 4, a percentage reported as activity, at one concentration (the size of the read-out at that concentration, not a potency): 99%
Estimate against measurement, compound 4: 4 percentage points below; low and high end bracket the measured number.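

In this assay, hydrogen in place of methoxy on an aromatic carbon gave a number 3.5 percentage points higher from compound 2 to compound 4 (within the scatter), and this step can be set beside the same change on the other core: the same change on two cores in this assay, a number 1.7 percentage points lower (within the scatter) from compound 1 to compound 3 and a number 3.5 percentage points higher (within the scatter) from compound 2 to compound 4, 5.2 percentage points apart, within the scatter of two such steps. The change therefore carries from the core of compound 1 to the core of compound 2 without a step beyond the scatter on either core, and the two steps cannot be told apart. This does not show that the steps are equal in size, that their opposite signs are real, or that the change would stay this small at any other concentration or in any other read-out.

Open, on these data alone, is how a group other than methoxy or hydrogen would read at these places, for example an amine or a carboxylic acid. Also open, as far as these compounds go, is whether a longer chain in place of the one joining the two aromatic rings would leave the read-out in this assay within the same scatter.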